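Thiosemicarbazide series: removing the ring methyl

The source may report more compounds than this note shows. Statements on the series, on what has been measured and on what is new or still open speak of the compounds shown alone.

Going by the values given here, compound 2 `Cc1cccc(/C(N)=N/NC(=S)N2CCCC2)n1` is one of two compounds measured so far. In a functional assay on HeLa cells (Homo sapiens) for cytotoxicity, read by MTT assay, with a stated time of 72 h, tested at 30 uM (on this read-out higher numbers stand for more inhibition of growth at the one concentration tested and lower numbers for less inhibition of growth), compound 2 gives 74.5%. Compound 1 `N/C(=N\NC(=S)N1CCCCC1)c1ccccn1` gives 76.9% in this assay, so the two numbers sit within the scatter of each other and neither can be set above the other. Compound 3 `N/C(=N\NC(=S)N1CCCC1)c1ccccn1` differs from compound 2 by hydrogen in place of methyl on an aromatic carbon. Among the compounds with values here, no step between measured compounds is available for this change; in this assay a step no larger than the scatter is expected, with no clear direction. Compound 3 is estimated at 76%, between 62% and 88%. This corresponds to an expected step of a number 1.5 percentage points higher from compound 2 to compound 3 (within the scatter).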

Compound 3, percent growth inhibition at one concentration: 84.5%
Compound 3: middle estimate off by 8.5 percentage points, on the low side; the range from low to high includes it.
By their numbers in this assay, from the lowest: compounds 2, 1 and 3 (each within the scatter of the next).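

In this assay hydrogen in place of methyl on an aromatic carbon next to the ring nitrogen gives a number 10 percentage points higher from compound 2 to compound 3 (within the scatter) and so shows that growth inhibition at this position is kept without the methyl. Pyrrolidin-1-yl in place of piperidin-1-yl on the thiocarbonyl carbon gives a number 7.6 percentage points higher from compound 1 to compound 3 (within the scatter) and so also shows no separable difference. No measurement bears on a cause for either step.

Open, going by these compounds, is whether an ethyl, methoxy or amino group at this position, or a morpholin-4-yl group on the thiocarbonyl carbon, would give a step beyond the scatter.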